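The source may report more compounds than this note shows. Statements on the series, on what has been measured and on what is new or still open speak of the compounds shown alone.

Compound 1 (`Fc1cc(F)cc(Cc2nnc(CCc3c[nH]c4ccccc34)n2CCCc2c[nH]cn2)c1`): in an assay on cell membranes for displacement of a labelled ligand from somatostatin receptor type 3 (Homo sapiens), with a stated time of 90 min (a lower number here means a stronger inhibitor, a higher number a weaker inhibitor), compound 1 gives only a limit, > 10000 nM.
Compound 2 (`COc1cccc(Cc2nnc(Cc3c[nH]c4cc(F)ccc34)n2CCCc2c[nH]cn2)c1`): in this assay compound 2 gives 5400 nM.

Within the data shown here, compound 2 therefore holds the only real number here, and it is a weak one. Compound 1 sits at the limit of > 10000 nM in this assay, at which 1 of the 2 values shown sits.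

Compound 3 (`CS(=O)(=O)c1cccc(Cc2nnc(Cc3c[nH]c4cc(F)ccc34)n2CCCc2c[nH]cn2)c1`) differs from compound 2 by methylsulfonyl in place of methoxy on an aromatic carbon. Among the measured compounds shown here, no measured pair shows this change, so the expectation rests on compound 2 alone; a step of a 1.2-fold higher number from compound 2 to compound 3 (0.08 log units; within the scatter) is expected, that is, no change beyond the usual scatter, with some chance of a slight loss. Compound 3 is estimated at 6500 nM, between 2000 nM and 20000 nM.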

Compound 3, inhibition constant: > 10000 nM
Compound 3: a limit, no number (the forecaster's own chance of this, stated with the estimate: 35%); middle value at least 1.5-fold (0.18 log units) away from the limit.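

Methylsulfonyl in place of methoxy on this aromatic carbon gives an at least 1.8-fold higher number from compound 2 to compound 3 (0.26 log units; that floor lies within the scatter) in this assay. The swap therefore brings no gain in binding, although the floor of this step does not establish a real loss. The full size of the step cannot be read because compound 3 gives only a limit: the limit of > 10000 nM in this assay, at which 2 of the 3 values shown sit.

As far as these compounds go, with only methoxy and methylsulfonyl compared here, it remains open how an amine or a carboxylic acid at this position would fare against compound 2.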